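Swapping nitro for methoxy on the core of compound 2

The source may hold more compounds than are shown below. What is called first, only, known or untested is meant among the compounds shown, and "the series" means these compounds.

Measured compounds:
- compound 1, `COc1ccc(Nc2cncc(N3CC4CC(C3)N4)c2)cc1`: 0.0598 nM
- compound 2, `O=[N+]([O-])c1ccc(Nc2ccc(N3CC4CC(C3)N4)cn2)cc1`: 1.76 nM
- compound 3, `Fc1ccc(Nc2ccc(N3CC4CC(C3)N4)nn2)cc1`: 868 nM

In an assay on cell membranes for displacement of a labelled ligand from Neuronal acetylcholine receptor; alpha4/beta2 (Rattus norvegicus) (a lower number here means a stronger inhibitor, a higher number a weaker inhibitor), compound 2 gives 1.76 nM, the second highest of the three numbers. Compound 1 lies at a much lower number, and compound 3 at a much higher one; both gaps are beyond the usual scatter. Compound 1 and compound 3 each carry a different core, so their values speak only for themselves and not for the effect of the substituent alone.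

Compound 4, `COc1ccc(Nc2ccc(N3CC4CC(C3)N4)cn2)cc1`, keeps the core of compound 2 and differs in one place: methoxy in place of nitro on an aromatic carbon. Among the compounds with values here, no measured pair shows this exact exchange on this core, so the direction of the step is open. Within the data shown here, compound 1, the only other methoxy-bearing compound, gives a low number, but on another core. A modest step is expected for compound 4, leaning toward a lower number yet possibly within the scatter, a 1.8-fold lower number from compound 2 to compound 4 (0.25 log units; within the scatter). Compound 4 is therefore estimated at 1 nM, with a range from 0.2 nM to 5 nM.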

Compound 4, inhibition constant: 7.3 nM
Compound 4: middle estimate off by 7.3-fold (0.86 log units), on the low side; measured number outside the range, above it.
By their numbers in this assay, from the lowest: compound 1; then compound 2; then compound 4; then compound 3.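

Within the data shown here, on the shared core, putting methoxy in place of nitro on the aromatic carbon para to a large group gives, in this assay, a 4.1-fold higher number from compound 2 to compound 4 (0.62 log units; beyond the scatter) as the only direct reading of this change. Nitro is therefore the better of these two groups at this position on this core: the step is modest, but it stands clear of the usual scatter. Nothing measured here accounts for the direction of this step.

A single pair cannot show how other groups at this position would rank, such as an amine, a nitrile, a carboxylic acid or a longer chain like ethoxy. On these data alone, it also remains open whether the same exchange would run the same way on the cores of compound 1 and compound 3.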